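The compounds below may be only part of what the source reports. "The series", "measured", "known", "first", "only" and "open" are said of these compounds alone.

In a functional assay on HeLa cells (Homo sapiens) for antiproliferative activity, read by MTT assay, with a stated time of 72 h (a higher number here means a weaker inhibitor, a lower number a stronger inhibitor), compound 1 `COc1cccc(N2C(=O)COc3ccc(-c4cnc(Cl)c(NS(=O)(=O)c5ccc(F)cc5)c4)cc32)c1` gives > 40000 nM, which is a limit and not a number. Compound 2 `COc1cccc(N2C(=O)COc3ccc(-c4cnc(OC)c(NS(=O)(=O)c5ccc(F)cc5)c4)cc32)c1` gives > 40000 nM, again a limit of the assay. So far the record is the limit of > 40000 nM in this assay, at which 2 of the 2 values shown sit, and compound 2 therefore has no exact value to build on.

Compound 3 `COc1ncc(-c2ccc3c(c2)N(C2CC2)C(=O)CO3)cc1NS(=O)(=O)c1ccc(F)cc1` keeps the rest of compound 2 but carries cyclopropyl in place of 3-methoxyphenyl on an amide-type nitrogen in a ring.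

For the measured compounds named here, the only measured change is a step that the two limits leave unreadable from compound 1 to compound 2. It concerns methoxy in place of chloro on an aromatic carbon, not this nitrogen, and it offers no size to carry over. The expectation for the new change is therefore loose. Going by the values given here, compound 2 sits at > 40000 nM, which is a limit, so the only readable change expected in this assay is toward a stronger inhibitor. The step expected is an at least 1.6-fold lower number from compound 2 to compound 3 (0.20 log units; that floor lies within the scatter), and this is only a rough estimate. For compound 3 the estimated value is 25000 nM, with an expected range from 3000 nM to 80000 nM.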

Compound 3, half-maximal inhibitory concentration: 6030 nM
Beside the measured number, compound 3's estimate is 4.1-fold (0.62 log units) above it; the range from low to high includes it.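

In this assay, the group on the amide-type nitrogen in the ring proves able to move the read-out: cyclopropyl in place of 3-methoxyphenyl gives an at least 6.6-fold lower number from compound 2 to compound 3 (0.82 log units; beyond the scatter). For the compounds shown here, the one earlier step, methoxy in place of chloro on an aromatic carbon, cannot be read, as both of its values are limits, so this is the first change with a readable size. Compound 3 also gives the series its first exact number, against which later changes can be sized, while the other compounds offer only a limit: the limit of > 40000 nM in this assay, at which 2 of the 3 values shown sit.

The swap changes several things at once, replacing a six-membered aromatic ring with a three-membered non-aromatic ring, reducing the heavy atoms and removing a hydrogen-bond acceptor, and this single step cannot separate these differences. From the compounds shown here alone, it remains open how a plain phenyl, an ethyl chain or a cyclohexyl ring on this nitrogen would compare, and whether chloro in place of methoxy would have a readable effect with cyclopropyl on the nitrogen.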